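The compounds below may be only part of what the source reports. "The series", "measured", "known", "first", "only" and "open" are said of these compounds alone.

Measured so far in an assay on isolated protein for binding affinity to Melanocortin receptor 4 (Homo sapiens); on this read-out higher numbers stand for weaker inhibition and lower numbers for stronger inhibition:
compound 1 `COc1ccc(Br)cc1CCc1c(Cl)cccc1-c1nccn1C(C)C` gives 670 nM
compound 2 `CCCn1ccnc1-c1cccc(Cl)c1CCc1cc(Br)ccc1OC` gives 1300 nM
compound 3 `CCC(C)n1ccnc1-c1cccc(Cl)c1CCc1cc(Br)ccc1OC` gives 2500 nM

Compound 3 has the highest of the three numbers in this assay; its gap to compound 2 is within the scatter, while the step of a 3.7-fold higher number from compound 1 to compound 3 (0.57 log units; beyond the scatter) lies beyond it. Compound 4 `COc1ccc(Br)cc1CCc1c(Cl)cccc1-c1nccn1CC1CC1` differs from compound 3 by cyclopropylmethyl in place of sec-butyl on an aromatic nitrogen. Among the compounds with values here, three measured steps bear on this change, all of them swaps of the group on the same aromatic nitrogen: a 1.9-fold higher number from compound 1 to compound 2 (0.29 log units; within the scatter), a 1.9-fold higher number from compound 2 to compound 3 (0.28 log units; within the scatter) and a 3.7-fold higher number from compound 1 to compound 3 (0.57 log units; beyond the scatter). Exchanging one small alkyl group for another of similar size moved the number little, and only the extra methyl that builds up sec-butyl gave a modest step. Cyclopropylmethyl keeps the four carbons of sec-butyl but, like propyl, is not branched at the carbon bound to the aromatic nitrogen. For compound 4 the expected change is therefore a 1.7-fold lower number from compound 3 to compound 4 (0.22 log units; within the scatter), likely not beyond the scatter. The estimate for compound 4 is 1500 nM, with a range from 600 nM to 4000 nM.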

Compound 4, inhibition constant: 2000 nM
Estimate against measurement, compound 4: 1.3-fold (0.12 log units) below; low and high end bracket the measured number.
By their numbers in this assay, from the lowest: compounds 1, 2, 4 and 3 (each within the scatter of the next, the first and the last beyond it).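

In this assay, a three-membered carbon ring in the group on this aromatic nitrogen leaves compound 4 within the scatter of its two open-chain relatives, the sec-butyl compound (a 1.3-fold lower number from compound 3 to compound 4 (0.10 log units; within the scatter)) and the propyl compound (a 1.5-fold higher number from compound 2 to compound 4 (0.19 log units; within the scatter)). Against the isopropyl compound, the step (a 3.0-fold higher number from compound 1 to compound 4 (0.47 log units; beyond the scatter)) lies beyond the scatter, so cyclopropylmethyl sits with sec-butyl on the same side of that gap, while propyl stays within the scatter of both compound 1 and compound 4. No evidence is available to explain these differences.

Still open, on these data alone, is how this position responds to a much smaller group such as methyl or to a longer chain such as hexyl. As far as these compounds go, an amine or a carboxylic acid carried on the chain also remains untested in these compounds.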